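The source may hold more compounds than are shown below. What is called first, only, known or untested is meant among the compounds shown, and "the series" means these compounds.

The measured compounds:
compound 1, `O=C(N/N=C\c1ccc(O)cc1)Nc1nnc(COc2ccc3ccccc3c2)o1`, 300 mg/kg
compound 2, `C/C(=N/NC(=O)Nc1nnc(COc2ccc3ccccc3c2)o1)c1ccc([N+](=O)[O-])cc1`, 300 mg/kg

In a functional assay on the whole organism (strain Wistar) with Rattus norvegicus as the target, with a stated time of 4 h (a lower number here means that less compound is needed, a higher number that more compound is needed for the effect), compound 1 gives 300 mg/kg, and in the same test compound 2 gives 300 mg/kg. On these numbers compound 2 stands level with compound 1; the two values agree within the scatter, so neither can be called more active than the other.

Compound 3, `C/C(=N/NC(=O)Nc1nnc(COc2ccc3ccccc3c2)o1)c1ccc(N)cc1`, has not yet been tested. Compared with compound 2 the structure differs in one place: amino in place of nitro on an aromatic carbon. Among the compounds with values here, no pair of measured compounds shows what this change does in this assay, so nothing in the data points in either direction. The step from compound 2 to compound 3 is therefore expected to be no change at the digits printed from compound 2 to compound 3 (within the scatter), that is, nothing beyond the scatter. For compound 3 the estimated value in this assay is 300 mg/kg, with a range from 150 mg/kg to 600 mg/kg.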

Compound 3, minimum effective dose: 300 mg/kg
For compound 3 middle estimate and measured number coincide at the digits printed; the measured number falls inside the stated range.
By their numbers in this assay, from the lowest: compounds 1, 2 and 3 (each within the scatter of the next).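

Within the data shown here, compound 3 gives the first direct reading of this position in this assay: with amino in place of nitro on an aromatic carbon, para to a large group, the result is no change at the digits printed from compound 2 to compound 3 (within the scatter), so replacing 4-nitrophenyl with 4-aminophenyl leaves the minimum effective dose unchanged. Compound 3 also connects to compound 1 through a single difference, the group on the amide-type nitrogen, and that comparison reads no change at the digits printed from compound 1 to compound 3 (within the scatter), so this change too has no visible effect in this assay. Nothing available explains why these values coincide.

From the compounds shown here alone, whether another group at this place, such as a carboxylic acid or a methoxy group, would shift the dose in this assay remains open. So does whether any change to the shared core would move it.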